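A few compounds are considered here, and "the series" means these few. Any claim that something is new, unique, unknown or untested is made for them only; others in the source may bear on it.

Measured so far in a functional assay on HCT-116 cells (Homo sapiens) for cytotoxicity, read by sulforhodamine B assay, with a stated time of 2 days; a higher number here means a weaker inhibitor, a lower number a stronger inhibitor:

- compound 1 `OCc1cc(N2CCCC2)ccc1-c1nc2c(s1)C(O)CCC2` gives 21000 nM as a number
- compound 2 `Cc1cc(N(C)C)ccc1-c1nc2c(s1)[C@H](O)CCC2` gives > 100000 nM as a limit

Compound 2 stands at > 100000 nM in this assay and this is a limit of the assay, not a number. Compound 3 `Cc1cc(N(C)C)ccc1-c1nc2c(s1)[C@@H](O)CCC2` keeps the same atoms and bonds as compound 2, and the comparison reads the two compounds have the same atoms and bonds and differ only in configuration as drawn: 1 of 1 stereo elements differ; a stereocentre at a saturated ring carbon is drawn R in compound 2 and S in compound 3 in full. In words, a stereocentre at a saturated ring carbon is drawn R in compound 2 and S in compound 3. No step beyond the usual scatter is expected in this assay and neither direction is favoured, so compound 3 may also reach the limit. The estimated change is a number no higher from compound 2 to compound 3 (the limit leaves the size open) and it is expected to stay small. For compound 3 the estimated value is 100000 nM with an expected range from 30000 nM to 200000 nM in this measurement.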

Compound 3, half-maximal inhibitory concentration: 127000 nM
Compound 3: middle estimate off by 1.3-fold (0.10 log units), on the low side; low and high end bracket the measured number.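

Among these compounds, no step from compound 2 to compound 3 can be read in this assay because the value of compound 2 is a limit of the assay and not a number: the limit of > 100000 nM in this assay, at which 1 of the 3 values shown sits. The compounds shown leave open whether the configuration at the saturated ring carbon changes the effect on these cells.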